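A few compounds are considered here, and "the series" means these few. Any claim that something is new, unique, unknown or untested is made for them only; others in the source may bear on it.

In a functional assay on U2OS cells for antagonist activity at C-X-C chemokine receptor type 3 (Homo sapiens), read by beta-arrestin recruitment (a higher number here means a weaker inhibitor, a lower number a stronger inhibitor), compound 1 `Cc1nc(-c2nc3ccccc3[nH]2)c(N2CCN(C(=O)Cn3cnc4cccnc43)[C@H](C)C2)s1` gives 1050 nM. Compound 2 `C[C@@H]1CN(c2sc(C3CC3)nc2-c2nc3ccccc3[nH]2)CCN1C(=O)Cn1cnc2cccnc21` gives 745 nM in this assay, a change described by a 1.4-fold lower number from compound 1 to compound 2 (0.15 log units; within the scatter). Compound 3 `C[C@@H]1CN(c2sc(CO)nc2-c2nc3ccccc3[nH]2)CCN1C(=O)Cn1cnc2cccnc21` reaches only > 10000 nM in this assay, which is a limit rather than a number, and it sits at the limit of > 10000 nM in this assay, at which 1 of the 3 values shown sits. Compound 3 thus stands as the weakest of the three measured compounds, with an at least 9.5-fold higher number from compound 1 to compound 3 (0.97 log units; beyond the scatter) and an at least 13-fold higher number from compound 2 to compound 3 (1.12 log units; beyond the scatter). Compound 4 `C[C@@H]1CN(c2sc(C3COC3)nc2-c2nc3ccccc3[nH]2)CCN1C(=O)Cn1cnc2cccnc21` differs from compound 3 by oxetan-3-yl in place of hydroxymethyl on an aromatic carbon. The two steps that bear on this change are those that brought in the hydroxymethyl group, each beyond the scatter and each toward weaker inhibition, so removing that group in favour of a ring is expected to bring the number down markedly, an at least 5.0-fold lower number from compound 3 to compound 4 (0.69 log units; beyond the scatter). Compound 4 is therefore estimated at 2000 nM, in a range from 600 nM to 10000 nM.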

Compound 4, half-maximal inhibitory concentration: 6220 nM
The estimate for compound 4 lay 3.1-fold (0.49 log units) below the measured number, within the range that was stated.
By their numbers in this assay, from the lowest: compounds 2 and 1 (each within the scatter of the next); then compound 4. At a limit, above all of these: compound 3.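

A ring alone at this position does not keep the number low: oxetan-3-yl in place of cyclopropyl gives an 8.3-fold higher number from compound 2 to compound 4 (0.92 log units; beyond the scatter), and in place of methyl it gives a 5.9-fold higher number from compound 1 to compound 4 (0.77 log units; beyond the scatter). Oxetan-3-yl in place of hydroxymethyl shows no firm difference, with an at least 1.6-fold lower number from compound 3 to compound 4 (0.20 log units; that floor lies within the scatter). Compound 3 remains a limit, not a number: the limit of > 10000 nM in this assay, at which 1 of the 4 values shown sits.

As far as these compounds go, whether a cyclobutyl ring or a methoxymethyl chain at this position would fall nearer compound 2 or nearer compound 4 stays open. So does the question of whether an amine such as azetidin-3-yl would be tolerated here.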